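The source may hold more compounds than are shown below. What is called first, only, known or untested is meant among the compounds shown, and "the series" means these compounds.

Compound 1 `CC1=C(/C=C/C(=O)/C=C/c2ccccc2C(F)(F)F)C(C)(C)CCC1O` was tested in a functional assay on PC-3 cells (Homo sapiens) for cytotoxicity, read by MTT assay, with a stated time of 72 h (on this read-out higher numbers stand for weaker inhibition and lower numbers for stronger inhibition), and gives 3700 nM. Compound 2 `CC1=C(/C=C/C(=O)/C=C/c2cc(C(F)(F)F)ccc2C(F)(F)F)C(C)(C)CCC1O` differs from compound 1 in one place: trifluoromethyl in place of hydrogen on an aromatic carbon. In this assay compound 2 gives 1900 nM, so the step of a 1.9-fold lower number from compound 1 to compound 2 (0.29 log units; within the scatter) is small. Compound 3 `CC1=C(/C=C/C(=O)/C=C/c2ccccc2F)C(C)(C)CCC1O` has a different core from compound 1, and the difference between the two cores is fluoro in place of trifluoromethyl on an aromatic carbon. In this assay compound 3 gives 10400 nM, and the step of a 2.8-fold higher number from compound 1 to compound 3 (0.45 log units; beyond the scatter) lies beyond the usual scatter.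

Compound 4 `CC1=C(/C=C/C(=O)/C=C/c2cccc(C(F)(F)F)c2F)C(C)(C)CCC1O` has not yet been measured. It differs from compound 3 by trifluoromethyl in place of hydrogen on an aromatic carbon. This is the same kind of change as from compound 1 to compound 2, and among the compounds shown it occurs two times in all; the surroundings are not the same, however. In compound 2 the new group sits meta to a large group and para to a trifluoromethyl group, whereas in compound 4 it sits ortho to a fluoro group and meta to a large group. Going by the values given here, the only measured precedent is the pair from compound 1 to compound 2, where the step was a 1.9-fold lower number from compound 1 to compound 2 (0.29 log units; within the scatter). On that basis a step of roughly a 1.7-fold lower number from compound 3 to compound 4 (0.24 log units; within the scatter) is expected from compound 3 to compound 4 in this assay, because a 1.9-fold lower number from compound 1 to compound 2 (0.29 log units; within the scatter) was modest. With a single precedent and a different neighbouring group, the range is kept wide. Compound 4 is therefore estimated at 6000 nM in this assay, with a likely span from 2500 nM to 14000 nM.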

Compound 4, half-maximal inhibitory concentration: 2100 nM
Compound 4: the middle estimate sits 2.9-fold (0.46 log units) above what was measured; the whole stated range lies above it.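

In this assay, putting trifluoromethyl in place of hydrogen on the core that carries the fluoro group gives a 5.0-fold lower number from compound 3 to compound 4 (0.69 log units; beyond the scatter), and this step on its own lies beyond the usual scatter of repeated measurements. Set beside the earlier step of the same kind, it does not differ by more than two such steps can differ by chance, so the data give no sign that the change behaves differently on the two cores: the same change on two cores in this assay, a 1.9-fold lower number (0.29 log units; within the scatter) from compound 1 to compound 2 and a 5.0-fold lower number (0.69 log units; beyond the scatter) from compound 3 to compound 4, 2.5-fold (0.41 log units) apart, within the scatter of two such steps. Going by these compounds alone, this does not show that the change reliably lowers the number, since only the step on the fluoro core lies clearly beyond the scatter, and two pairs cannot fix how large the step would be on a further core or explain its size.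

The aromatic substituents shown are limited to fluoro and trifluoromethyl groups, so it remains open how a chlorine atom, a methoxy group, a nitrile or an amine would read in this assay when carried on the same ring. It also remains open whether the alcohol on the non-aromatic part of the shared core matters, as every compound shown carries it, and whether these steps would hold in any other cell line.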